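Replacing (pyrrolidin-2-yl)methyl with 1-acetylpiperidin-3-yl on compound 3

The source may hold more compounds than are shown below. What is called first, only, known or untested is meant among the compounds shown, and "the series" means these compounds.

Values so far in a physicochemical assay for solubility, at pH 7.4 (on this read-out higher numbers stand for higher solubility and lower numbers for lower solubility), are as follows
- Compound 1 `O=C(N[C@H]1CN(S(=O)(=O)c2ccccc2)C[C@@H]1C(=O)N[C@H]1CCCNC1)c1cn(C2CC2)cn1` gives 664000 nM
- Compound 2 `Cc1oc(-c2ccc(C(F)(F)F)cc2)nc1C(=O)N[C@H]1CN(S(=O)(=O)c2ccccc2)C[C@@H]1C(=O)N[C@H]1CCCNC1` gives 13000 nM
- Compound 3 `O=C(N[C@H]1CN(S(=O)(=O)c2ccccc2)C[C@@H]1C(=O)NC[C@@H]1CCCN1)c1cc(-c2ccccc2Cl)on1` gives 503000 nM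

In this assay compound 3 stands within the scatter of compound 1, and far beyond the scatter above compound 2. Compound 4 `CC(=O)N1CCC[C@H](NC(=O)[C@H]2CN(S(=O)(=O)c3ccccc3)C[C@@H]2NC(=O)c2cc(-c3ccccc3Cl)on2)C1` has not yet been measured. The change from compound 3 is 1-acetylpiperidin-3-yl in place of (pyrrolidin-2-yl)methyl on an amide-type nitrogen and it puts 1-acetylpiperidin-3-yl in place of (pyrrolidin-2-yl)methyl on an amide-type nitrogen.

Among the compounds with values here, no two measured compounds differ in one place only, so no measured step speaks directly to this change. Within the data shown here, the only guide is the spread of the measured values, where compound 2 at 13000 nM marks the low end. A fall beyond the scatter in this assay is expected, with wide uncertainty. The estimated step is an 8.4-fold lower number from compound 3 to compound 4 (0.92 log units; beyond the scatter) in this account. The estimate for compound 4 is 60000 nM (expected range 12000 nM to 250000 nM).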

Compound 4, solubility: < 500 nM
Compound 4: no number, only a limit; the forecaster's own chance of this, stated with the estimate: 5%; middle value at least 120-fold (2.07 log units) from the limit.
By their numbers in this assay, from the lowest: compound 2; then compounds 3 and 1 (each within the scatter of the next). At a limit, below all of these: compound 4.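

Within the data shown here, putting 1-acetylpiperidin-3-yl in place of (pyrrolidin-2-yl)methyl on the amide-type nitrogen gives an at least 1000-fold lower number from compound 3 to compound 4 (3.00 log units; beyond the scatter) in this assay, and this is the first step in the set that differs in one place only. The earlier compounds shown here, which differ from one another in more than one place, could not show that this single place can carry a change of such size. Compound 4 has only a limit of the assay, not a number: the limit of < 500 nM in this assay, at which 1 of the 4 values shown sits.

The compounds shown leave open whether the acetyl group or the six-membered ring accounts for this step, and how large the step really is. They also leave open how 1-methylpiperidin-3-yl, or an open-chain amine such as 2-aminoethyl, would read on this nitrogen.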